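The source may hold more compounds than are shown below. What is called first, only, known or untested is meant among the compounds shown, and "the series" means these compounds.

Compound 1 `CCc1nnc(SCC(=O)c2ccc(C)cc2)n1N1C(=O)c2ccccc2C1=O` was examined in a functional assay on PC-3M cells (Homo sapiens) for cytotoxicity, read by MTT assay, with a stated time of 48 h; a lower number here means a stronger inhibitor, a higher number a weaker inhibitor. In this assay compound 1 returns only a limit of the assay, > 200000 nM, and not a number. Compound 2 `CCc1nnc(SC)n1N1C(=O)c2ccccc2C1=O` carries hydrogen in place of (4-methylphenyl)carbonyl on a saturated chain carbon bound to a sulfur. In this assay compound 2 likewise reaches only the limit, > 200000 nM. Between the two lies a step that the two limits leave unreadable from compound 1 to compound 2, so the size of this change cannot be read from that pair because both values sit at the limit of > 200000 nM in this assay, at which 2 of the 3 values shown sit. Among the measured compounds shown here, compound 3 `COc1cc(-c2nnc(SCC(=O)c3ccc(C)cc3)n2N2C(=O)c3ccccc3C2=O)cc(OC)c1OC` differs from compound 1 in its core by 3,4,5-trimethoxyphenyl in place of ethyl on an aromatic carbon, and in this assay compound 3 gives 11700 nM, the only number among the three measured compounds. That difference amounts to an at least 17-fold lower number from compound 1 to compound 3 (1.23 log units; beyond the scatter). Compound 4 `COc1cc(-c2nnc(SC)n2N2C(=O)c3ccccc3C2=O)cc(OC)c1OC` has not yet been measured; it stands to compound 3 as compound 2 stands to compound 1, with hydrogen in place of (4-methylphenyl)carbonyl on a saturated chain carbon bound to a sulfur, the same change on a saturated chain carbon bound to a sulfur. The earlier instance of this change yielded no readable size. For the measured compounds named here, the expectation for compound 4 rests only on compound 3, which at 11700 nM is the single compound here that gave a number while both compounds with the ethyl core gave none. Compound 4 is therefore expected to give 50000 nM, within 12000 nM to 200000 nM. The step that this estimate means is expected to be a 4.3-fold higher number from compound 3 to compound 4 (0.63 log units; beyond the scatter), with a real chance that only a limit is reported.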

Compound 4, half-maximal inhibitory concentration: > 200000 nM
Compound 4 ended at the assay's limit (the forecaster's own chance of this, stated with the estimate: 45%); middle value at least 4.0-fold (0.60 log units) from the limit.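

In this assay, among the compounds shown here, hydrogen in place of (4-methylphenyl)carbonyl on a saturated chain carbon bound to a sulfur gives an at least 17-fold higher number from compound 3 to compound 4 (1.23 log units; beyond the scatter), so on the core bearing 3,4,5-trimethoxyphenyl the only measured number is lost with this change. Compound 4 returns only a limit of the assay and not a number, and it joins most of the compounds shown: the limit of > 200000 nM in this assay, at which 3 of the 4 values shown sit. The same change on the core of compound 1, leading to compound 2, cannot be read, so this series offers a single readable instance and does not show whether the change has a similar size on both cores.

The compounds shown leave open which part of the (4-methylphenyl)carbonyl matters, as only that group and hydrogen are compared on this saturated chain carbon, and a plain phenylcarbonyl, a carboxylic acid or an amine there would help to separate the contribution of the aromatic ring from that of the carbonyl. They also leave open how much of the 3,4,5-trimethoxyphenyl is needed, as a single methoxy on the phenyl ring, or an unsubstituted phenyl, would show whether a number returns in this assay with less of that group.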